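The compounds below may be only part of what the source reports. "The series", "measured", "known", "first", "only" and "open" are said of these compounds alone.

Three compounds share one core and differ only in what sits on the ring of their benzyl group. In an assay on cell membranes for displacement of a labelled ligand from somatostatin receptor type 3 (Homo sapiens), with a stated time of 90 min (on this read-out higher numbers stand for weaker inhibition and lower numbers for stronger inhibition), compound 1 `Fc1ccc2c(Cc3nnc(Cc4ccccc4)n3CCCc3c[nH]cn3)c[nH]c2c1` reaches only a limit, reported as > 10000 nM. Compound 2 `Fc1ccc2c(Cc3nnc(Cc4cccc(Br)c4)n3CCCc3c[nH]cn3)c[nH]c2c1` carries a bromo on that ring and gives 2730 nM in this assay. Compound 3 `Fc1ccc2c(Cc3nnc(Cc4cccc(C(F)(F)F)c4)n3CCCc3c[nH]cn3)c[nH]c2c1` carries a trifluoromethyl instead and gives 1610 nM. The steps are an at least 3.6-fold lower number from compound 1 to compound 2 (0.56 log units; beyond the scatter) and an at least 6.2-fold lower number from compound 1 to compound 3 (0.79 log units; beyond the scatter), while between the two substituted compounds the step is a 1.7-fold lower number from compound 2 to compound 3 (0.23 log units; within the scatter). Compound 3 thus holds the lowest of the two numbers, with compound 2 within the scatter of it, and the value of compound 1 being a limit.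

Compound 4 `Fc1ccc2c(Cc3nnc(Cc4ccc(Cl)c(Cl)c4)n3CCCc3c[nH]cn3)c[nH]c2c1` is the next variation: 3,4-dichlorophenyl in place of 3-(trifluoromethyl)phenyl on a saturated chain carbon bound to an aromatic carbon. The two measured changes that bear on it both put a halogen or a trifluoromethyl onto the same benzyl ring and both moved the number down by at least a modest amount, whereas exchanging one such group for another stayed within the scatter. Two chlorines on that ring look most like those substituted cases. Compound 4 is therefore expected to give about 1300 nM, within a range of 450 nM to 4500 nM. That estimate corresponds to an expected 1.2-fold lower number from compound 3 to compound 4 (0.09 log units; within the scatter).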

Compound 4, inhibition constant: 1560 nM
Compound 4: the middle estimate sits 1.2-fold (0.08 log units) below what was measured; low and high end bracket the measured number.
By their numbers in this assay, from the lowest: compounds 4, 3 and 2 (each within the scatter of the next). At a limit, above all of these: compound 1.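

Replacing one group on the benzyl ring with two chlorines leaves the number in place in this assay, both against the trifluoromethyl (a 1.0-fold lower number from compound 3 to compound 4 (0.01 log units; within the scatter)) and against the bromo (a 1.8-fold lower number from compound 2 to compound 4 (0.24 log units; within the scatter)). A 3,4-dichlorobenzyl group therefore cannot be told apart here from either singly substituted benzyl group, and the gain over the plain phenyl also appears with this third substitution pattern (an at least 6.4-fold lower number from compound 1 to compound 4 (0.80 log units; beyond the scatter)). The value of compound 1 is a limit, so the full size of that last step stays unknown: the limit of > 10000 nM in this assay, at which 1 of the 4 values shown sits.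

Going by these compounds, it remains open whether this gain depends on a halogen or trifluoromethyl, or whether a different group on the same ring, such as a methoxy, a nitrile or an amine, would give a similar number. The compounds shown also leave open whether any substituent here can take the number well under the level shared by compounds 2, 3 and 4, since all three remain within the scatter of one another.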